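From Compound 3 to Compound 4: A Longer Chain

The source may hold more compounds than are shown below. What is called first, only, known or untested is meant among the compounds shown, and "the series" means these compounds.

Of the compounds shown here, three built on a shared core have been tested in a functional assay on HeLa cells (Homo sapiens) for antiproliferative activity, read by MTT assay, with a stated time of 48 h (a lower number here means a stronger inhibitor, a higher number a weaker inhibitor), so far. Compound 1 (`CN(C)CCCn1c(N)c(-c2nc3ccccc3[nH]2)c2nc(C#N)c(C#N)nc21`) gives 25900 nM as its result. Compound 2 (`CN(C)CCCn1c(N)c(-c2nc3ccccc3o2)c2nc(C#N)c(C#N)nc21`) gives 11200 nM in the same test. Within the data shown here, the one measured step, with 1,3-benzoxazol-2-yl in place of 1H-benzimidazol-2-yl, is a 2.3-fold lower number from compound 1 to compound 2 (0.36 log units; beyond the scatter) and counts as modest.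

Compound 3 (`CN(C)CCn1c(N)c(-c2nc3cc(Cl)ccc3[nH]2)c2nc(C#N)c(C#N)nc21`) has only a limit, > 50000 nM, as its result and not a number.

Compound 4 (`CN(C)CCCn1c(N)c(-c2nc3cc(Cl)ccc3[nH]2)c2nc(C#N)c(C#N)nc21`) differs from compound 3 in the side chain: (dimethylamino)methyl in place of dimethylamino on a saturated chain carbon, two bonds along the chain from an aromatic nitrogen turns 2-(dimethylamino)ethyl into 3-(dimethylamino)propyl. Among the measured compounds shown here, no measured step covers this chain change. The step of a 2.3-fold lower number from compound 1 to compound 2 (0.36 log units; beyond the scatter) lies at another place on the molecule and offers only a sense of how large one change can be here. The closer guide is compound 1, which carries the same 3-(dimethylamino)propyl chain and gives 25900 nM in this test. A modest move toward a lower number is therefore expected, estimated as an at least 1.7-fold lower number from compound 3 to compound 4 (0.25 log units; that floor lies within the scatter) for now, and compound 4 may also stay at the limit. In this assay compound 4 is estimated at 28000 nM with an expected range from 12000 nM to 50000 nM on this reading.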

Compound 4, half-maximal inhibitory concentration: 16500 nM
Compound 4: the middle estimate sits 1.7-fold (0.23 log units) above what was measured, and the stated range covers the measured number.
By their numbers in this assay, from the lowest: compounds 2, 4 and 1 (each within the scatter of the next, the first and the last beyond it). At a limit, above all of these: compound 3.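

Lengthening the side chain from 2-(dimethylamino)ethyl to 3-(dimethylamino)propyl gives the first direct reading of a change at this position: in this assay, the change amounts to an at least 3.0-fold lower number from compound 3 to compound 4 (0.48 log units; beyond the scatter). The true size of this step may be larger, because one end of it is a limit and not a number: the limit of > 50000 nM in this assay, at which 1 of the 4 values shown sits. The other two new steps, both among compounds carrying the 3-(dimethylamino)propyl chain, stay within the scatter, with chloro in place of hydrogen giving a 1.6-fold lower number from compound 1 to compound 4 (0.20 log units; within the scatter) and 5-chloro-1H-benzimidazol-2-yl in place of 1,3-benzoxazol-2-yl giving a 1.5-fold higher number from compound 2 to compound 4 (0.17 log units; within the scatter).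

The compounds shown cover only these two chain lengths alongside the 5-chloro-1H-benzimidazol-2-yl group, so it remains open whether a longer chain, such as 4-(dimethylamino)butyl, would continue the trend or reverse it. Also open, on these data alone, is whether the chain length alone matters or the end group does too, which a morpholine in place of dimethylamino at the end of the 3-carbon chain would help to separate.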